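Tert-butoxycarbonyl to carboxy: working notes on the series

This account rests on a few compounds, and the source may have more. Where it says the series, first, only, none or still open, it means among the compounds named here.

In an ADME assay on L6 cells (Rattus norvegicus) for cytotoxicity, read by resazurin assay, with a stated time of 72 h (on this read-out lower numbers stand for an effect already at smaller amounts and higher numbers for an effect only at larger amounts of compound), compound 1 `CCOC(=O)C1=C(C)N/C(=C/c2cc(C)n(-c3cccc(C(F)(F)F)c3)c2C)C1=O` gives 100000 nM as its value, and compound 2 `CCOC(=O)C1=C(C)N/C(=C/c2cc(C)n(-c3ccc(CN4CCCCC4)cc3)c2C)C1=O` gives 81000 nM on the same read-out. Compound 3 `CC1=C(C(=O)OC(C)(C)C)C(=O)/C(=C\c2cc(C)n(-c3ccccc3C(F)(F)F)c2C)N1` gives 110000 nM in this assay and so stands within the scatter of both compound 1 and compound 2. The three numbers form a single band with no order among them. Among the compounds with values here, no measured pair differs in one place only, so no single-change step is available as a guide.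

Compound 4 `CC1=C(C(=O)O)C(=O)/C(=C\c2cc(C)n(-c3ccccc3C(F)(F)F)c2C)N1` carries one change from compound 3 (hydrogen in place of tert-butyl on an oxygen next to a carbonyl group): hydrogen in place of tert-butyl on an oxygen next to a carbonyl group, which also reads tert-butoxycarbonyl to carboxy. No step beyond the scatter is expected in this assay, and neither direction is clearly favoured. The expectation starts from compound 3 at 110000 nM as its anchor. Within the data shown here, no measured compound here carries a carboxy group, so the range is kept wide. The step expected is a 1.1-fold higher number from compound 3 to compound 4 (0.04 log units; within the scatter) and that lies within the scatter. For compound 4 the estimated value is 120000 nM with an expected range from 60000 nM to 200000 nM as its upper end.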

Compound 4, half-maximal effective concentration in the L6 assay: 31000 nM
For compound 4 the middle estimate is 3.9-fold (0.59 log units) above the measured one, outside the stated range (below it).
By their numbers in the L6 assay, from the lowest: compound 4; then compounds 2, 1 and 3 (each within the scatter of the next).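

Within the data shown here, in the L6 assay the change from tert-butoxycarbonyl to carboxy gives a 3.5-fold lower number from compound 3 to compound 4 (0.55 log units; beyond the scatter), a modest step and the first that can be read beyond the scatter, whereas the earlier compounds formed a single band and offered no single-change step. In a physicochemical assay for solubility, read by nephelometry, in phosphate buffer, measured as kinetic solubility, at pH 6.5 (a higher number here means a more soluble compound, a lower number a less soluble compound), the same change shows no change at the digits printed from compound 3 to compound 4 (within the scatter), with compound 3 at 1.6 ug/mL and compound 4 at 1.6 ug/mL, so the replacement of tert-butyl by hydrogen on an oxygen next to a carbonyl group registers in one read-out and leaves the other as it stood. Nothing available on these compounds bears on the origin of the step, and it stays an observation on this single pair.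

From the compounds shown here alone, whether a carboxamide or a methyl ester in place of the carboxy group would stand with compound 3 or with compound 4 remains open. Also open, going by these compounds, is whether the same change, made on the ethyl esters compound 1 and compound 2 with their different groups on the shared core, would give a step of similar size.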